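Two Limit Values and a Chlorinated Third Analogue

The source may hold more compounds than are shown below. What is called first, only, known or untested is meant among the compounds shown, and "the series" means these compounds.

Compound 1 `N#CC1=C(N)Oc2c(c3nc4ccccc4nc3c3ccccc23)C12C(=O)N(Cc1cnnn1-c1ccc(S(N)(=O)=O)cc1)c1ccccc12` gives > 50000 nM in a functional assay on A549 cells (Homo sapiens) for antiproliferative activity, read by MTT assay, with a stated time of 48 h (on this read-out higher numbers stand for weaker inhibition and lower numbers for stronger inhibition), a limit of the assay.
Compound 2 `N#CC1=C(N)Oc2c(N)cc3nc4ccccc4nc3c2C12C(=O)N(Cc1cnnn1-c1ccc([N+](=O)[O-])cc1)c1ccccc12` gives > 50000 nM in this assay, again a limit.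

Compound 2 therefore stands at the limit of > 50000 nM in this assay, at which 2 of the 2 values shown sit, so no true number is known for it. Compound 3 `N#CC1=C(N)Oc2c(N)cc3nc4ccccc4nc3c2C12C(=O)N(Cc1cnnn1-c1ccc(Cl)cc1[N+](=O)[O-])c1ccccc12` is not yet measured; its change from compound 2 is 4-chloro-2-nitrophenyl in place of 4-nitrophenyl on an aromatic nitrogen. Within the data shown here, no measured step between compounds is available, so no shift beyond the usual scatter is expected from this change. Compound 3 is expected to give 60000 nM in this assay, within 20000 nM to 200000 nM. The expected step is a step that the limit leaves unreadable from compound 2 to compound 3, and most likely only a limit is reported again.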

Compound 3, half-maximal inhibitory concentration: > 50000 nM
Compound 3: only a limit was reported; the forecaster's own chance of this, stated with the estimate: 75%; the middle value lies beyond the limit too.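

No step can be read from compound 2 to compound 3, as both stand at the same limit: the limit of > 50000 nM in this assay, at which 3 of the 3 values shown sit.

The compounds shown leave open the true value of each, and whether 4-chloro-2-nitrophenyl in place of 4-nitrophenyl changes anything.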